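Thiophen-3-yl in place of thiophen-2-yl in compound 4

A few compounds are considered here, and "the series" means these few. Any claim that something is new, unique, unknown or untested is made for them only; others in the source may bear on it.

Compound 3 `Cc1ncnc2c1c(-c1cccs1)cn2[C@@H]1O[C@H](CO)[C@@H](O)[C@H]1O` gives > 15000 nM in a functional assay on HeLa S3 cells (Homo sapiens) for antiproliferative activity, read by XTT assay, with a stated time of 72 h (on this read-out lower numbers stand for stronger inhibition and higher numbers for weaker inhibition), which is a limit and not a number. Compound 4 `Cc1ncnc2c1c(-c1ccsc1)cn2[C@@H]1O[C@H](CO)[C@@H](O)[C@H]1O` differs from it in one group, with thiophen-3-yl in place of thiophen-2-yl on an aromatic carbon. Compound 1 `CNc1ncnc2c1c(-c1ccsc1)cn2[C@@H]1O[C@H](CO)[C@@H](O)[C@H]1O` already carries thiophen-3-yl and gives > 20000 nM in this assay, also a limit. Compound 2 `CN(C)c1ncnc2c1c(-c1ccsc1)cn2[C@@H]1O[C@H](CO)[C@@H](O)[C@H]1O` carries it too and gives > 15000 nM in this assay, again a limit. Going by the values given here, the only measured step is a step that the two limits leave unreadable from compound 1 to compound 2, so it offers no size to carry over. No change beyond the scatter is therefore expected, and the estimated step is a step that the limit leaves unreadable from compound 3 to compound 4. For compound 4 the expected value is 20000 nM, with an estimated range of 6000 nM to 40000 nM.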

Compound 4, half-maximal inhibitory concentration: 14300 nM
The estimate for compound 4 lay 1.4-fold (0.15 log units) above the measured number; the measured number falls inside the stated range.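

In this assay compound 4 is the first compound shown to give a number rather than a limit, so thiophen-3-yl at this position now has a measured value. The change from thiophen-2-yl amounts to an at least 1.0-fold lower number from compound 3 to compound 4 (0.02 log units; that floor lies within the scatter), while methyl in place of dimethylamino gives an at least 1.0-fold lower number from compound 2 to compound 4 (0.02 log units; that floor lies within the scatter) and methyl in place of methylamino gives an at least 1.3-fold lower number from compound 1 to compound 4 (0.14 log units; that floor lies within the scatter). None of these floors shows a change beyond the scatter, and the neighbouring compounds remain limits: the limit of > 15000 nM in this assay, at which 2 of the 4 values shown sit.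

On these data alone, the true size of each step stays open. So does the effect of a carboxylic acid or a longer chain in place of thiophen-3-yl on this aromatic carbon.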